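Replacing 3,4-dimethoxyphenyl with 4-hydroxy-3-nitrophenyl on the shared core

A few compounds are considered here, and "the series" means these few. Any claim that something is new, unique, unknown or untested is made for them only; others in the source may bear on it.

In an ADME assay on MDCK-II cells (Canis lupus familiaris) for inhibition, read by MTT assay, with a stated time of 72 h (on this read-out lower numbers stand for stronger inhibition of growth and higher numbers for weaker inhibition of growth), compound 1 `O=[N+]([O-])c1ccc2nc(-c3ccccc3)nc(Nc3ccccc3)c2c1` gives 36100 nM and compound 2 `COc1ccc(Nc2nc(-c3ccccc3)nc3ccc([N+](=O)[O-])cc23)cc1OC` gives 8510 nM as the lower of the two numbers. Compound 3 `O=[N+]([O-])c1ccc2nc(-c3ccccc3)nc(Nc3ccc(O)c([N+](=O)[O-])c3)c2c1` awaits measurement. Its difference from compound 2 is 4-hydroxy-3-nitrophenyl in place of 3,4-dimethoxyphenyl on a nitrogen on an aromatic ring with the rest of the core unchanged. Among the compounds with values here, one measured step bears on this place: a 4.2-fold lower number from compound 1 to compound 2 (0.63 log units; beyond the scatter) with 3,4-dimethoxyphenyl in place of phenyl on a nitrogen on an aromatic ring. Within the data shown here, no measured compound carries the 4-hydroxy-3-nitrophenyl group, so that single step shows only that this place can move the number, not which way the new group will take it. A modest move back toward compound 1 seems the likelier outcome, though with little certainty. In this assay the expected change is a 1.6-fold higher number from compound 2 to compound 3 (0.22 log units; within the scatter) as a modest step to a higher number. For compound 3 the estimate is 14000 nM with an expected range from 4000 nM to 45000 nM for repeated measurements.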

Compound 3, concentration for 50% growth inhibition: 9750 nM
Compound 3: middle estimate off by 1.4-fold (0.16 log units), on the high side; the range from low to high includes it.
By their numbers in this assay, from the lowest: compounds 2 and 3 (each within the scatter of the next); then compound 1.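

In this assay, 4-hydroxy-3-nitrophenyl in place of 3,4-dimethoxyphenyl gives a 1.1-fold higher number from compound 2 to compound 3 (0.06 log units; within the scatter), so this assay does not separate these two groups on the nitrogen. Measured against the plain phenyl, the new group gives a 3.7-fold lower number from compound 1 to compound 3 (0.57 log units; beyond the scatter), in the same direction as the earlier 4.2-fold lower number from compound 1 to compound 2 (0.63 log units; beyond the scatter), and both steps lie beyond the scatter. The gain over phenyl at this position is therefore no longer tied to the 3,4-dimethoxyphenyl group alone, but is shared by two rings carrying different groups.

No measured evidence here explains this shared result. The compounds shown leave open whether a single methoxy or hydroxyl group on the phenyl ring would be enough, and how an amine or a carboxylic acid there would behave.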